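Series notes: compound 1 and its ethoxy homologue

The source may report more compounds than this note shows. Statements on the series, on what has been measured and on what is new or still open speak of the compounds shown alone.

Compound 1 `COc1ccc(-c2ccc3ncn(-c4cc(OC)c(OC)c(OC)c4)c3c2)cc1` is the anchor of this set. In a functional assay on SGC-7901 cells (Homo sapiens) for antiproliferative activity, read by MTT assay, with a stated time of 72 h (on this read-out higher numbers stand for weaker inhibition and lower numbers for stronger inhibition), compound 1 gives 82 nM, the lowest number among the three measured compounds. Compound 2 `COc1cc(-n2cnc3ccc(-c4cccc([N+](=O)[O-])c4)cc32)cc(OC)c1OC` gives 380 nM and compound 3 `COc1cc(-n2cnc3ccc(-c4ccc(C)cc4F)cc32)cc(OC)c1OC` gives 5650 nM. Both steps away from compound 1 go upward: a 4.6-fold higher number from compound 1 to compound 2 (0.67 log units; beyond the scatter) and a 69-fold higher number from compound 1 to compound 3 (1.84 log units; beyond the scatter); between the two others, a 15-fold higher number from compound 2 to compound 3 (1.17 log units; beyond the scatter). All three of these changes swap the whole aryl group attached to the shared core, so the measured steps show that this aryl group matters, but they say nothing about small edits within the 4-methoxyphenyl of compound 1.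

Compound 4 `CCOc1ccc(-c2ccc3ncn(-c4cc(OC)c(OC)c(OC)c4)c3c2)cc1` keeps that aryl group and changes 4-methoxyphenyl to 4-ethoxyphenyl: methyl in place of hydrogen on a saturated chain carbon bound to an oxygen on an aromatic ring. Among the compounds with values here, no measured pair makes a change of this kind; the closest are the aryl swaps above, and those do not transfer to a single added methyl. For compound 4 the expected change is a 1.2-fold higher number from compound 1 to compound 4 (0.09 log units; within the scatter), a step expected to fall within the scatter, with no decided direction. The estimate for compound 4 is 100 nM, with a range from 40 nM to 250 nM.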

Compound 4, half-maximal inhibitory concentration: 2970 nM
Beside the measured number, compound 4's estimate is 30-fold (1.47 log units) below it, outside the stated range (above it).
By their numbers in this assay, from the lowest: compound 1; then compound 2; then compounds 4 and 3 (each within the scatter of the next).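

A single added methyl on the saturated chain carbon bound to an oxygen on an aromatic ring is enough to move the number in this assay: methoxy to ethoxy gives a 36-fold higher number from compound 1 to compound 4 (1.56 log units; beyond the scatter), so this position responds strongly to a small edit within the 4-methoxyphenyl of compound 1, which the whole-aryl swaps could not show. The 4-ethoxyphenyl group also leaves the series with a 7.8-fold higher number from compound 2 to compound 4 (0.89 log units; beyond the scatter), and against the 2-fluoro-4-methylphenyl group it shows a 1.9-fold lower number from compound 3 to compound 4 (0.28 log units; within the scatter), so on this read-out compound 4 and compound 3 cannot be told apart. Nothing in the information at hand accounts for the step from methoxy to ethoxy.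

Going by these compounds, this one pair gives no trend along the chain, so it remains open whether a longer chain such as propoxy, a branched isopropoxy or a hydroxy group would follow compound 4 or stay closer to compound 1. On these data alone, it also remains open whether the same methyl step would carry over to an aryl group with a different substitution pattern, such as a 3-methoxyphenyl.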